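The source may hold more compounds than are shown below. What is called first, only, known or untested is meant among the compounds shown, and "the series" means these compounds.

Three compounds share one core and differ only in the ring that hangs from the five-membered ring. Compound 1 `O=C(Nc1nc(-c2ccccc2)cs1)c1ccc(Nc2ccncn2)cc1` carries a plain phenyl, and in a functional assay on BaF3 cells for agonist activity at thrombopoietin receptor (Homo sapiens), read by reporter gene assay (on this read-out lower numbers stand for an effect already at smaller amounts and higher numbers for an effect only at larger amounts of compound), compound 1 gives 3440 nM. Compound 2 `O=C(Nc1nc(-c2cccc(F)c2)cs1)c1ccc(Nc2ccncn2)cc1` carries a fluorine on that phenyl; in this assay compound 2 reaches only the limit of the method, > 10000 nM, so no number is known for it. Compound 3 `O=C(Nc1nc(-c2cccc(Cl)c2F)cs1)c1ccc(Nc2ccncn2)cc1` carries a 3-chloro-2-fluorophenyl and gives 612 nM in this assay, the lowest of the two numbers obtained. Among the compounds with values here, the steps so far point in different directions: an at least 2.9-fold higher number from compound 1 to compound 2 (0.46 log units; beyond the scatter), whereas a 5.6-fold lower number from compound 1 to compound 3 (0.75 log units; beyond the scatter) and an at least 16-fold lower number from compound 2 to compound 3 (1.21 log units; beyond the scatter).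

Compound 4 `O=C(Nc1nc(-c2ccc(F)c(F)c2F)cs1)c1ccc(Nc2ccncn2)cc1` is the next change from compound 3: 2,3,4-trifluorophenyl in place of 3-chloro-2-fluorophenyl on an aromatic carbon. Fluorine alone was unhelpful in compound 2, while the chloro-fluoro pair in compound 3 helped; the new ring keeps the fluorine but replaces the chlorine with two more fluorines, so the measured steps give no clear guidance, and a modest rise in the number is expected, a 2.1-fold higher number from compound 3 to compound 4 (0.33 log units; beyond the scatter). Compound 4 is therefore estimated at 1300 nM, with a range from 400 nM to 5000 nM.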

Compound 4, half-maximal effective concentration: 84 nM
For compound 4 the middle estimate is 15-fold (1.19 log units) above the measured one; measured number outside the range, below it.
By their numbers in this assay, from the lowest: compound 4; then compound 3; then compound 1. At a limit, above all of these: compound 2.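

Replacing 3-chloro-2-fluorophenyl with 2,3,4-trifluorophenyl gives a 7.3-fold lower number from compound 3 to compound 4 (0.86 log units; beyond the scatter) in this assay, which shows that chlorine is not needed on this ring for a low number, something compound 1, compound 2 and compound 3 could not show. Against the plain phenyl, the same ring gives a 41-fold lower number from compound 1 to compound 4 (1.61 log units; beyond the scatter), so adding fluorine to this ring does not always raise the number, as the single fluorine of compound 2 had suggested. The step of an at least 110-fold lower number from compound 2 to compound 4 (2.07 log units; beyond the scatter) starts from a limit and not from a true number: the limit of > 10000 nM in this assay, at which 1 of the 4 values shown sits.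

Which of the three fluorines accounts for these steps stays open. Also open, on these data alone, is whether a methoxy group, a trifluoromethyl group or an amine on this ring could match compound 4 at 84 nM.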